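The source may report more compounds than this note shows. Statements on the series, on what has been measured and on what is new or still open speak of the compounds shown alone.

Measured compounds:
compound 1 `CC1(C)Oc2ccc(C(=O)Cc3ccccc3)cc2[C@@H](/N=C(\NC#N)Nc2ccc(Cl)cc2)[C@@H]1O` — 6800 nM
compound 2 `C=C(c1ccccc1)c1ccc2c(c1)[C@@H](/N=C(\NC#N)Nc1ccc(Cl)cc1)[C@H](O)C(C)(C)O2` — 10700 nM

In a functional assay (aorta) with Rattus norvegicus as the target (a higher number here means a weaker inhibitor, a lower number a stronger inhibitor), compound 1 gives 6800 nM and compound 2 gives 10700 nM; the two stand within the scatter of each other. Compound 3 `CC1(C)Oc2ccc(S(=O)(=O)N3CCOCC3)cc2[C@@H](/N=C(\NC#N)Nc2ccc(Cl)cc2)[C@@H]1O` differs from compound 1 in one place: (morpholin-4-yl)sulfonyl in place of benzylcarbonyl on an aromatic carbon. Within the data shown here, the only measured step, a 1.6-fold higher number from compound 1 to compound 2 (0.20 log units; within the scatter), concerns a different entering group and stays within the scatter, so it gives no direction for this change. No step beyond the scatter is expected in this assay. The expected step is a 1.0-fold higher number from compound 1 to compound 3 (0.01 log units; within the scatter). Compound 3 is estimated at 7000 nM, between 1500 nM and 30000 nM.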

Compound 3, half-maximal inhibitory concentration: 3100 nM
Compound 3: the middle estimate sits 2.3-fold (0.35 log units) above what was measured; the measured number falls inside the stated range.
By their numbers in this assay, from the lowest: compound 3; then compounds 1 and 2 (each within the scatter of the next).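

In this assay, the change to (morpholin-4-yl)sulfonyl brings a 2.2-fold lower number from compound 1 to compound 3 (0.34 log units; beyond the scatter) and, against 1-phenylethenyl, a 3.5-fold lower number from compound 2 to compound 3 (0.54 log units; beyond the scatter). Benzylcarbonyl and 1-phenylethenyl stood within the scatter of each other, so this is the first sign that the group on this aromatic carbon can move the number, here with an entering group that has no aromatic ring and the same heavy-atom count as benzylcarbonyl. Still open, as far as these compounds go, is whether a carboxylic acid or a primary amine on this carbon would move the number further, and whether a dimethylaminosulfonyl group would match the morpholine-bearing one. Nothing in the data shown accounts for these steps.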